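The source may hold more compounds than are shown below. What is called first, only, known or untested is meant among the compounds shown, and "the series" means these compounds.

Working notes on the series. Compound 1 `COc1ccc(S(N)(=O)=O)cc1C(=O)Nc1cccc(-c2nncn2C(C)C)n1` gives 18% in an assay for inhibition of mitogen-activated protein kinase kinase kinase kinase 4 (Homo sapiens), tested at 1 uM; on this read-out higher numbers stand for more inhibition at the one concentration tested (going by the name of the read-out) and lower numbers for less inhibition. Compound 2 `COc1cc(C)c(S(N)(=O)=O)cc1C(=O)Nc1cccc(-c2nncn2C(C)C)n1` gives 44% in this assay, and compound 3 `COc1ccc(S(C)(=O)=O)cc1C(=O)Nc1cccc(-c2nncn2C(C)C)n1` gives 12%. On these three numbers compound 3 stands lowest; compound 1 lies within the scatter of it, compound 2 lies beyond it. Two single-point steps have been measured: one gave a number 26 percentage points higher from compound 1 to compound 2 (beyond the scatter), the other gave a number 6 percentage points lower from compound 1 to compound 3 (within the scatter).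

Compound 4 `COc1cc(C)c(S(C)(=O)=O)cc1C(=O)Nc1cccc(-c2nncn2C(C)C)n1` has not yet been measured in this assay. It differs from compound 3 by methyl in place of hydrogen on an aromatic carbon. Among the compounds with values here, the step that bears on it is the one that gave a number 26 percentage points higher from compound 1 to compound 2 (beyond the scatter), the same change made on the sulfonamide pair. Within the data shown here, the step that gave a number 6 percentage points lower from compound 1 to compound 3 (within the scatter) shows that the two sulfonyl groups give like numbers, so the methyl is expected to add a similar modest rise here, though only one such pair supports it. Compound 4 is therefore expected to give 35%, within 18% to 55%. This estimate means an expected a number 23 percentage points higher from compound 3 to compound 4 (beyond the scatter).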

Compound 4, a percentage reported as inhibition, at one concentration (the size of the read-out at that concentration, not a potency): 20%
Compound 4: middle estimate off by 15 percentage points, on the high side, and the stated range covers the measured number.
By their numbers in this assay, from the lowest: compounds 3, 1 and 4 (each within the scatter of the next); then compound 2.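

In this assay the methyl on the aromatic carbon ortho to a methylsulfonyl group gives a number 8 percentage points higher from compound 3 to compound 4 (within the scatter), so the rise seen on the sulfonamide pair does not carry over to this pair: the same change on two cores in this assay, a number 26 percentage points higher (beyond the scatter) from compound 1 to compound 2 and a number 8 percentage points higher (within the scatter) from compound 3 to compound 4, 18 percentage points apart, beyond the scatter of two such steps. Read from the other side, methyl in place of amino on the sulfonyl sulfur gives a number 24 percentage points lower from compound 2 to compound 4 (beyond the scatter) when the aromatic methyl is present, unlike the same change without it: the same change on two cores in this assay, a number 6 percentage points lower (within the scatter) from compound 1 to compound 3 and a number 24 percentage points lower (beyond the scatter) from compound 2 to compound 4, 18 percentage points apart, beyond the scatter of two such steps. The two changes therefore do not simply add, and what the aromatic methyl does at this position depends on the group on the sulfonyl sulfur, though each reading rests on a single pair.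

On these data alone, it remains open whether ethyl or chloro on the same aromatic carbon would follow the methyl on either sulfonyl group. As far as these compounds go, it also remains open whether dimethylamino on the sulfonyl sulfur would behave like amino or like methyl.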